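This account rests on a few compounds, and the source may have more. Where it says the series, first, only, none or still open, it means among the compounds named here.

In an ADME assay on Huh7.5.1 cells (Homo sapiens) for cytotoxicity, read by ATP content, with a stated time of 48 h (on this read-out higher numbers stand for lower toxicity in this test and lower numbers for higher toxicity in this test), compound 1 `Cc1ccc(C)c(-c2nc(CN3CCC(C(=O)NCCCN4C[C@H](C)C[C@H](C)C4)CC3)c(C)o2)c1` gives 4070 nM and compound 2 `Cc1cc(C)c(-c2nc(CN3CCC(C(=O)NCCCN4C[C@H](C)C[C@H](C)C4)CC3)c(C)o2)c(C)c1` gives 6570 nM. Compound 3 `CC[C@@H]1C[C@H](CC)CN(CCCNC(=O)C2CCN(Cc3nc(-c4ccccc4C)oc3C)CC2)C1` gives 3470 nM, within the usual scatter of both other numbers, so the three cannot be told apart. Compound 4 `Cc1ccccc1-c1nc(CN2CCC(C(=O)NCCCN3CC(C)(C)CC(C)(C)C3)CC2)c(C)o1` has the same atoms as compound 3, joined differently: a group of 10 heavy atoms (9 carbon, 1 nitrogen; one six-membered non-aromatic ring with 1 hetero atom) in place of a group of 10 heavy atoms (9 carbon, 1 nitrogen; one six-membered non-aromatic ring with 1 hetero atom), on a saturated chain carbon, three bonds along the chain from an amide-type nitrogen. The 3,5-diethylpiperidin-1-yl group is the part that leaves. Among the compounds with values here, the only measured step, a 1.6-fold higher number from compound 1 to compound 2 (0.21 log units; within the scatter), changes a different group and stays within the scatter, so it offers only weak guidance, and no measured step touches this group. The expected change is small, a 1.2-fold higher number from compound 3 to compound 4 (0.06 log units; within the scatter), and no shift beyond the scatter is expected in either direction. For compound 4 the estimated value is 4000 nM, with an expected range of 2000 nM to 8000 nM.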

Compound 4, half-maximal cytotoxic concentration: 4380 nM
Estimate against measurement, compound 4: 1.1-fold (0.04 log units) below; low and high end bracket the measured number.
By their numbers in this assay, from the lowest: compounds 3, 1, 4 and 2 (each within the scatter of the next).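

In this assay, putting a group of the same atoms, joined differently, in place of the 3,5-diethylpiperidin-1-yl group gives a 1.3-fold higher number from compound 3 to compound 4 (0.10 log units; within the scatter) and so does not separate the two compounds. At this place on the chain, then, rearranging these atoms within a six-membered ring and losing the 2 defined stereocentres leaves the number within the scatter. Nothing measured here offers an explanation for this result. Still open, as far as these compounds go, is whether a morpholine ring, a pyrrolidine ring or an open-chain diethylamino group at the same place would also stay within the scatter.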